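The source may report more compounds than this note shows. Statements on the series, on what has been measured and on what is new or still open speak of the compounds shown alone.

Values in a functional assay on MDA-MB-231 cells (Homo sapiens) for antiproliferative activity, with a stated time of 5 days; a higher number here means a weaker inhibitor, a lower number a stronger inhibitor:
- compound 1 `O=C1C=CC2(C=C1)OCC(=O)N2c1nc(-c2ccc3c(c2)OCCO3)nn1-c1ccccc1`: 100 nM
- compound 2 `O=C1C=CC2(C=C1)OCC(=O)N2c1nc(-c2cccc3ccccc23)nn1-c1ccccc1`: 50 nM
- compound 3 `O=C1C=CC2(C=C1)OCC(=O)N2c1nc(-c2ccc3ccccc3c2)nn1-c1ccccc1`: 70 nM

Compound 3 is not separated from either neighbour: the data show a 1.4-fold lower number from compound 1 to compound 3 (0.15 log units; within the scatter) and a 1.4-fold higher number from compound 2 to compound 3 (0.15 log units; within the scatter). All three compounds therefore form a single group of values.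

The next compound, compound 4 `O=C1C=CC2(C=C1)OCC(=O)N2c1nc(-c2cccc(Cl)c2)nn1-c1ccccc1`, has 3-chlorophenyl in place of naphthalen-2-yl on an aromatic carbon of the five-membered aromatic ring with 3 nitrogen (3-chlorophenyl in place of naphthalen-2-yl on an aromatic carbon).

Going by the values given here, the steps that bear on this change are the other swaps at the same place. Besides those above, the data show a 2.0-fold lower number from compound 1 to compound 2 (0.30 log units; within the scatter). Among the compounds with values here, none of these steps goes beyond the scatter, though no measured compound carries a chlorine-substituted group, so the evidence is indirect. In this assay, no step beyond the scatter is expected, and no direction can be firmly assigned. The expected step is a 1.3-fold higher number from compound 3 to compound 4 (0.11 log units; within the scatter). For compound 4 the estimated value is 90 nM, with an expected range of 35 nM to 220 nM.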

Compound 4, half-maximal inhibitory concentration: 0.8 nM
For compound 4 the middle estimate is 110-fold (2.05 log units) above the measured one, outside the stated range (below it).
By their numbers in this assay, from the lowest: compound 4; then compounds 2, 3 and 1 (each within the scatter of the next).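

In this assay, the earlier swaps at this place, on an aromatic carbon of the five-membered aromatic ring with 3 nitrogen, suggested a position indifferent to the aryl group, yet a single change to 3-chlorophenyl gives an 88-fold lower number from compound 3 to compound 4 (1.94 log units; beyond the scatter), a 63-fold lower number from compound 2 to compound 4 (1.80 log units; beyond the scatter) and a 130-fold lower number from compound 1 to compound 4 (2.10 log units; beyond the scatter). The position is therefore highly sensitive to the group it carries, which naphthalen-1-yl, naphthalen-2-yl and 2,3-dihydro-1,4-benzodioxin-6-yl did not reveal, since they remain within the scatter of one another. No measurement available here accounts for this large step.

As far as these compounds go, whether the chlorine or the single six-membered ring carries the gain stays open, as a plain phenyl group at this place would separate the two. Also open, from the compounds shown here alone, is whether the gain survives with a bromine, a methoxy group or an amine in place of the chlorine.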